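The compounds below may be only part of what the source reports. "The series", "measured", "known", "first", "only" and "open" are said of these compounds alone.

In an in vitro ADME assay on microsomes from liver (Mus musculus) for pharmacokinetics, read by LC-MS, with a stated time of 10 min, tested at 1 uM (on this read-out lower numbers stand for slow clearance and higher numbers for fast clearance), three compounds sharing one core have been measured. Compound 1 (`CN1C[C@H](C(=O)Nc2ccc(C#N)cc2)[C@@H](c2ccc(/C=C/C(=O)Nc3ccccc3N)cc2)C1`) gives 35 mL/min/kg, compound 2 (`CN1C[C@H](C(=O)Nc2ccc(C3CC3)cc2)[C@@H](c2ccc(/C=C/C(=O)Nc3ccccc3N)cc2)C1`) gives 60 mL/min/kg, and compound 3 (`CN1C[C@H](C(=O)Nc2ccc(Cl)c(Cl)c2)[C@@H](c2ccc(/C=C/C(=O)Nc3ccccc3N)cc2)C1`) gives 36 mL/min/kg, so compound 3 lies within the scatter of both others. Compound 4 (`Cc1ccc(NC(=O)[C@H]2CN(C)C[C@@H]2c2ccc(/C=C/C(=O)Nc3ccccc3N)cc2)cn1`) departs from compound 3 as follows: 6-methylpyridin-3-yl in place of 3,4-dichlorophenyl on an amide-type nitrogen. This places 6-methylpyridin-3-yl in place of 3,4-dichlorophenyl on an amide-type nitrogen. Two measured steps change that same place: a 1.0-fold higher number from compound 1 to compound 3 (0.01 log units; within the scatter), and a 1.7-fold lower number from compound 2 to compound 3 (0.22 log units; within the scatter). Among the measured compounds shown here, no measured compound carries a ring with a hetero atom there, which leaves the expectation uncertain. The expected change is a 1.0-fold lower number from compound 3 to compound 4 (0.01 log units; within the scatter), nothing beyond the scatter in this assay. For compound 4 the estimated clearance is 35 mL/min/kg, with an expected range of 18 mL/min/kg to 65 mL/min/kg.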

Compound 4, clearance: 57 mL/min/kg
Compound 4: the middle estimate sits 1.6-fold (0.21 log units) below what was measured, and the stated range covers the measured number.
By their numbers in this assay, from the lowest: compounds 1, 3, 4 and 2 (each within the scatter of the next).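

With a ring carrying a hetero atom now on the amide-type nitrogen in this assay, the steps of a 1.6-fold higher number from compound 3 to compound 4 (0.20 log units; within the scatter) and a 1.1-fold lower number from compound 2 to compound 4 (0.02 log units; within the scatter) and a 1.6-fold higher number from compound 1 to compound 4 (0.21 log units; within the scatter) all stay within the scatter. The four groups seen at this place, 6-methylpyridin-3-yl among them, are therefore not told apart by this read-out. No supporting data bear on these readings.

On these data alone, whether an amine or a carboxylic acid on this ring, or a longer chain in its place, would give a step beyond the scatter remains open.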